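Shortening the alkoxy chain on the shared benzotriazine dioxide core

The compounds below may be only part of what the source reports. "The series", "measured", "known", "first", "only" and "open" are said of these compounds alone.

Measured compounds:
compound 1 `CCCOCNc1n[n+]([O-])c2cc(OC)ccc2[n+]1[O-]` — 12000 nM
compound 2 `COc1ccc2c(c1)[n+]([O-])nc(NCOC(C)c1ccccc1)[n+]2[O-]` — 12400 nM
compound 3 `CCCCCOCNc1n[n+]([O-])c2ccccc2[n+]1[O-]` — 39500 nM

In a functional assay on KB cells (Homo sapiens) for cytotoxicity, read by MTT assay, with a stated time of 72 h (a higher number here means a weaker inhibitor, a lower number a stronger inhibitor), compound 3 stands with the highest number of the three, beyond the scatter from compound 2 and from compound 1. Compound 4 `CCOCNc1n[n+]([O-])c2ccccc2[n+]1[O-]` is not yet measured; it differs from compound 3 in one place: hydrogen in place of propyl on a saturated chain carbon, two bonds along the chain from an oxygen on a saturated carbon. Among the measured compounds shown here, the only single-point step among the measured compounds, a 1.0-fold higher number from compound 1 to compound 2 (0.01 log units; within the scatter), alters the group on the other side of the oxygen and tells little about chain length itself. Compound 1 and compound 3 differ in more than one place, so their gap cannot be assigned to the chain. For the measured compounds named here, no measured step therefore bears directly on this change, and a step within the scatter, a 1.3-fold lower number from compound 3 to compound 4 (0.12 log units; within the scatter), is expected. Compound 4 is estimated at 30000 nM, with a range from 10000 nM to 90000 nM.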

Compound 4, half-maximal inhibitory concentration: 22500 nM
For compound 4 the middle estimate is 1.3-fold (0.12 log units) above the measured one; low and high end bracket the measured number.
By their numbers in this assay, from the lowest: compounds 1, 2, 4 and 3 (each within the scatter of the next, the first and the last beyond it).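

In this assay, among the compounds shown here, a 1.8-fold lower number from compound 3 to compound 4 (0.24 log units; within the scatter) gives the first direct reading on chain length at this position, which the earlier compounds could not give. On the shared core, going from pentyloxy to ethoxy, with hydrogen in place of propyl, stays within the scatter, so this shortening has no measurable effect on the number. Nothing available here accounts for this result.

On these data alone, whether a longer chain such as octyloxy, or an amine in place of propyl, would also stay within the scatter remains open. So does whether the same shortening would read alike on the core of compound 1.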